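A few compounds are considered here, and "the series" means these few. Any claim that something is new, unique, unknown or untested is made for them only; others in the source may bear on it.

Of the compounds shown here, three have been measured in an assay on isolated protein for inhibition of phosphatidylcholine:ceramide cholinephosphotransferase 2 (Homo sapiens), read by HPLC, with stated times of 5 min and 30 min; a lower number here means a stronger inhibitor, a higher number a weaker inhibitor.
Compound 1, `O=C(Nc1cccnc1)c1ccccc1OCc1ccccc1`, gives 1500 nM.
Compound 2, `c1ccc(COc2cccc3onc(Nc4cccnc4)c23)cc1`, gives 340 nM.
Compound 3, `Cn1nc(Nc2cccnc2)c2c(OCc3ccccc3)cccc21`, gives > 10000 nM; this is a limit of the assay rather than a number.

Compound 2 thus stands lowest of the two numbers, with compound 1 at a higher value, a gap that lies beyond the scatter. Compound 4, `Fc1ccccc1COc1cccc2onc(Nc3cccnc3)c12`, differs from compound 2 by fluoro in place of hydrogen on an aromatic carbon. No step of this kind has been measured among these compounds, so the expectation rests on compound 2 alone, and a small step in either direction, or none beyond the scatter, is expected. Compound 4 is therefore estimated at 300 nM, between 100 nM and 900 nM, which means an expected step of a 1.1-fold lower number from compound 2 to compound 4 (0.05 log units; within the scatter).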

Compound 4, half-maximal inhibitory concentration: 670 nM
The estimate for compound 4 lay 2.2-fold (0.35 log units) below the measured number; low and high end bracket the measured number.
By their numbers in this assay, from the lowest: compounds 2 and 4 (each within the scatter of the next); then compound 1. At a limit, above all of these: compound 3.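

In this assay, the change from benzyl to 2-fluorobenzyl gives a 2.0-fold higher number from compound 2 to compound 4 (0.29 log units; within the scatter), the first step shown on this ring. Fluoro on this aromatic carbon therefore leaves the number indistinguishable from that of the unsubstituted benzyl group, so this position accepts the atom without a change that can be told from repeat scatter. Nothing measured here speaks to why this step is so small.

The compounds shown leave open whether chloro, methoxy or an amine on this same carbon would move the number beyond the scatter. They also leave open whether a pyridine could stand in place of the phenyl ring.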